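The source may hold more compounds than are shown below. What is called first, only, known or untested is meant among the compounds shown, and "the series" means these compounds.

Measured so far:
Compound 1 `CCc1nc(-c2ccc(OC)cc2OC(F)(F)F)c(CC)nc1NC(CC)CC`: 0.267 h
Compound 2 `CCc1nc(-c2ccc(Cl)cc2Cl)c(CC)nc1NC(COC)COC`: 0.15 h

In an in vitro ADME assay on microsomes (Homo sapiens) for metabolic stability (a higher number here means that the compound lasts longer, a lower number that the compound disappears faster), compound 2 gives 0.15 h. This lies within the usual scatter of compound 1 at 0.267 h, so the two numbers cannot be ranked.

The next compound is compound 3 `CCCN(CCN(C)C)c1nc(CC)c(-c2ccc(Cl)cc2Cl)nc1CC`, which has not yet been measured. It differs from compound 2 by one change: (2-(dimethylamino)ethyl)(propyl)amino in place of (2-methoxy-1-(methoxymethyl)ethyl)amino on an aromatic carbon.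

Among the compounds with values here, no measured pair differs in one place only, so the size of this change has no direct precedent. The expectation therefore rests on compound 2 at 0.15 h as the starting point. The expected result is a 1.3-fold lower number from compound 2 to compound 3 (0.10 log units; within the scatter), leaning slightly downward and not beyond the scatter. Compound 3 is estimated at 0.12 h, with an expected range of 0.05 h to 0.3 h.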

Compound 3, half-life: 0.0833 h
Beside the measured number, compound 3's estimate is 1.4-fold (0.16 log units) above it; the measured number falls inside the stated range.
By their numbers in this assay, from the lowest: compounds 3, 2 and 1 (each within the scatter of the next, the first and the last beyond it).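

In this assay, within the data shown here, the exchange of (2-methoxy-1-(methoxymethyl)ethyl)amino for (2-(dimethylamino)ethyl)(propyl)amino on the aromatic carbon para to a 2,4-dichlorophenyl group gives a 1.8-fold lower number from compound 2 to compound 3 (0.26 log units; within the scatter) and is the first comparison that differs in one place. At this position, a chain with no hydrogen-bond donor and no oxygen therefore gives a number that cannot be told apart from that of the chain with one donor and two oxygens. No measurement at hand explains this result.

As far as these compounds go, the donor, the oxygens and the second nitrogen all differ together, so the contribution of each remains open. Also open, from the compounds shown here alone, is whether a morpholine ring or a carboxylic acid on this carbon would move the half-life beyond the scatter.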